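The source may report more compounds than this note shows. Statements on the series, on what has been measured and on what is new or still open speak of the compounds shown alone.

Working notes on the series, read in an ADME assay on LLC-MK2 cells (Macaca mulatta) for cytotoxicity, read by spectrophotometry and crystal violet staining, with a stated time of 4 days; on this read-out higher numbers stand for lower toxicity in this test and lower numbers for higher toxicity in this test. Compound 1 `CC(C)n1ncc2c(C(=O)Nc3ccccn3)cc(-c3ccsc3)nc21` gives 25000 nM. Compound 2 `CC(C)n1ncc2c(C(=O)Nc3ccc(F)cc3)cc(-c3ccsc3)nc21` gives > 200000 nM, which is a limit of the assay and not a number. Its place in the series is therefore known only as a limit, and any step starting from it carries that uncertainty.

Compound 3 `CC(C)n1ncc2c(C(=O)Nc3ccncn3)cc(-c3ccsc3)nc21` has pyrimidin-4-yl in place of 4-fluorophenyl on an amide-type nitrogen. For the measured compounds named here, only one measured step bears on this change: an at least 8.0-fold higher number from compound 1 to compound 2 (0.90 log units; beyond the scatter), where 4-fluorophenyl replaced pyridin-2-yl at the same place. That step is beyond the scatter. The incoming pyrimidin-4-yl is closer to the pyridin-2-yl of compound 1 than to the group it replaces, so a step of similar size is expected in the reverse direction, towards lower numbers, with compound 1 at 25000 nM as the nearest reference. The expected move is an at least 5.0-fold lower number from compound 2 to compound 3 (0.69 log units; beyond the scatter). Compound 3 is estimated at 40000 nM, with an expected range of 12000 nM to 150000 nM.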

Compound 3, half-maximal cytotoxic concentration: > 200000 nM
Compound 3: only a limit was reported; the forecaster's own chance of this, stated with the estimate: 15%; middle value at least 5.0-fold (0.69 log units) from the limit.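

On an amide-type nitrogen, pyrimidin-4-yl in place of pyridin-2-yl gives an at least 8.0-fold higher number from compound 1 to compound 3 (0.90 log units; beyond the scatter) in this assay. A six-membered aromatic ring with hetero atoms at this place therefore does not in itself go with the lower number, and the higher number is not tied to the carbon-only ring of 4-fluorophenyl, so that among the three compounds shown only compound 1 gives a readable number. Compound 2 and compound 3 are both known only as limits of the assay, so the step between them cannot be read, and the series sits at the top of the read-out: the limit of > 200000 nM in this assay, at which 2 of the 3 values shown sit.

As far as these compounds go, how compound 2 and compound 3 compare stays open, as does how far each lies from the limit. Also open, from the compounds shown here alone, is whether the lower number belongs to pyridin-2-yl alone or would return with other groups on the same amide-type nitrogen, such as pyridin-3-yl, a saturated ring like piperidin-4-yl, or a phenyl ring carrying a carboxylic acid.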